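Ethoxycarbonyl in Place of Fluoro: Expected Dose in Rats

The source may report more compounds than this note shows. Statements on the series, on what has been measured and on what is new or still open speak of the compounds shown alone.

Compound 1 `CCOC(=O)C(=O)Nc1nc(-c2ccc(F)cc2)cs1` gives > 10 mg/kg in a functional assay on the whole organism with Rattus norvegicus as the target (a higher number here means that more compound is needed for the effect, a lower number that less compound is needed), a limit of the assay rather than a number.
Compound 2 `CCOC(=O)C(=O)Nc1nc(-c2ccccc2OC)cs1` gives > 30 mg/kg in this assay, which is also a limit of the assay.
Compound 3 `CC(=O)Nc1ccc(-c2csc(NC(=O)C(N)=O)n2)cc1` gives > 10 mg/kg in this assay, again a limit of the assay.

The three measured compounds share a core and differ only in the groups attached to the six-membered aromatic ring. Compound 1 stands at a limit and nowhere else: no number is known for it in this assay, and the two other values are limits as well. Two of the three values sit at the limit of > 10 mg/kg in this assay, at which 2 of the 3 values shown sit, and one at the limit of > 30 mg/kg in this assay, at which 1 of the 3 values shown sits. Among the compounds with values here, no pair of measured compounds differs in just one place, so no measured step is available to show how a change on this ring shifts the dose.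

Compound 4 `CCOC(=O)C(=O)Nc1nc(-c2ccc(C(=O)OCC)cc2)cs1` has not been measured yet. Compared with compound 1, (ethoxycarbonyl in place of fluoro on an aromatic carbon). Because every measured value is a limit, including the limit of > 10 mg/kg in this assay, at which 2 of the 3 values shown sit, for compound 1, the step that the limit leaves unreadable from compound 1 to compound 4 is expected to be none beyond the scatter. Compound 4 is therefore estimated at 30 mg/kg, with a range from 10 mg/kg to 100 mg/kg, most probably reported again as a limit only.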

Compound 4, dose for half-maximal effect: > 10 mg/kg
Compound 4 ended at the assay's limit; the forecaster's own chance of this, stated with the estimate: 75%; the middle value is on the limit's open side.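

In this assay compound 4 gives > 10 mg/kg, a limit of the assay. Compound 1 also stands at a limit, and the step from compound 1 to compound 4 cannot be read. The compounds shown leave open what dose any of them actually needs for the effect.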